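Fluoro in place of ethyl on compound 1

The compounds below may be only part of what the source reports. "The series", "measured", "known", "first", "only" and "open" are said of these compounds alone.

Compound 1 `CCc1cn([C@H]2C[C@H](N=[N+]=[N-])[C@@H](CO)O2)c(=O)[nH]c1=O` gives > 100 ug/mL in an ADME assay on Huh-7 cells (Homo sapiens) for cytotoxicity, read by XTT assay (a higher number here means that more compound is tolerated, a lower number that less compound is tolerated), and this is a limit of the assay, not a number. Compound 2 `CCc1cn([C@H]2CC[C@@H](CO)O2)c(=O)[nH]c1=O` gives > 100 ug/mL as a limit too. Compound 3 `CCc1cn([C@H]2C[C@H](F)[C@@H](CO)O2)c(=O)[nH]c1=O` gives > 100 ug/mL as a limit too. The picture so far is the limit of > 100 ug/mL in this assay, at which 3 of the 3 values shown sit, and nothing finer.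

Compound 4 `[N-]=[N+]=N[C@H]1C[C@H](n2cc(F)c(=O)[nH]c2=O)O[C@@H]1CO` brings fluoro in place of ethyl on an aromatic carbon to the core of compound 1, that is, fluoro in place of ethyl on an aromatic carbon.

The measured steps are a step that the two limits leave unreadable from compound 1 to compound 2 and a step that the two limits leave unreadable from compound 1 to compound 3 and also a step that the two limits leave unreadable from compound 2 to compound 3 in this set. All of them fall on a saturated ring carbon, none touches the ethyl group, and none has a readable size. They therefore give only weak guidance for this change, and no step beyond the scatter is expected in this assay on that basis.

The expected change is a number no higher from compound 1 to compound 4 (the limit leaves the size open) as an estimate only, with some risk of lower tolerance. The estimated value for compound 4 is 100 ug/mL with an expected range of 40 ug/mL to 200 ug/mL in all.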

Compound 4, half-maximal cytotoxic concentration: > 100 ug/mL
Compound 4 gave a limit, no number; the forecaster's own chance of this, stated with the estimate: 75%; the middle value sits exactly at the limit.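

Compound 4 gives > 100 ug/mL in this assay, a limit and not a number. Within the data shown here, compound 1 also stands at a limit, so no step from compound 1 to compound 4 can be read. The compounds shown leave open how much compound each tolerates, as all remain at one limit: the limit of > 100 ug/mL in this assay, at which 4 of the 4 values shown sit.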